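The source may hold more compounds than are shown below. What is called first, only, known or untested is meant among the compounds shown, and "the series" means these compounds.

Of the compounds shown here, three built on one shared core have been tested in a functional assay on MCF7 cells (Homo sapiens) for inhibition, read by MTT assay, with a stated time of 24 h; on this read-out lower numbers stand for stronger inhibition and higher numbers for weaker inhibition. Compound 1 `CCOC(=O)C1=Cc2ccccc2OC1(OCc1cn(CC(=O)Nc2ccc(C)cc2)nn1)C(F)(F)F` gives in this assay a value of > 150000 nM, which is a limit of the assay rather than a number. Compound 2 `O=C(O)C1=Cc2ccccc2OC1(OCc1cc(-c2ccc([N+](=O)[O-])cc2)no1)C(F)(F)F` likewise reaches only the limit > 150000 nM in this assay. Compound 3 `CCOC(=O)C1=Cc2ccccc2OC1(OCc1cc(-c2ccc(Br)cc2)no1)C(F)(F)F` also sits at the limit > 150000 nM in this assay. Among the measured compounds shown here, compound 1 thus stands together with its companions at the limit of > 150000 nM in this assay, at which 3 of the 3 values shown sit, and no measured step between any two of them can be drawn from these numbers.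

Compound 4 `CCOC(=O)C1=Cc2ccccc2OC1(OCc1cn(-c2ccc(C)cc2)nn1)C(F)(F)F` has not yet been measured. It differs from compound 1 in one place: 4-methylphenyl in place of ((4-methylphenyl)carbamoyl)methyl on an aromatic nitrogen. The shared core is left untouched, and the change is confined to the substituent on that aromatic nitrogen. Because every value shown sits at the limit of > 150000 nM in this assay, at which 3 of the 3 values shown sit, there is no ground for expecting a step beyond the scatter in either direction. In this assay the expected a number no higher from compound 1 to compound 4 (the limit leaves the size open) is therefore none that the assay would resolve. Compound 4 is estimated at 150000 nM in this assay, within a range from 50000 nM to 400000 nM, and the most probable outcome is that the assay once more reports only its limit.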

Compound 4, half-maximal inhibitory concentration: 26700 nM
Compound 4: the middle estimate sits 5.6-fold (0.75 log units) above what was measured, outside the stated range (below it).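

The substituent on the aromatic nitrogen of the five-membered ring turns out to matter: with 4-methylphenyl in place of ((4-methylphenyl)carbamoyl)methyl, this assay gives an at least 5.6-fold lower number from compound 1 to compound 4 (0.74 log units; beyond the scatter), and the limit on compound 1 leaves the full size of this step open. Among the compounds shown here, what leaves is the amide link, while the six-membered aromatic ring of carbon with its methyl group stays, so an aryl group carried directly on this nitrogen is compatible with a measurable value, which the earlier compounds could not show. Compound 4 is also the only compound shown that gives a number rather than a limit: the limit of > 150000 nM in this assay, at which 3 of the 4 values shown sit.

For the compounds shown here, the single step cannot separate the loss of the amide from the shortening of the chain, and a benzyl group on the same nitrogen would be needed to tell these apart. Going by these compounds, whether the methyl group on the phenyl ring contributes also stays open, as does the effect of a chlorine or methoxy group in its place or of a carboxylic acid in place of the ethyl ester of compound 4.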